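Hydroxy for bromo on the benzodioxane core

The source may report more compounds than this note shows. Statements on the series, on what has been measured and on what is new or still open speak of the compounds shown alone.

In an assay on Cerebral cortex (strain Sprague-Dawley) for displacement of a labelled ligand from Neuronal acetylcholine receptor; alpha4/beta2 (Rattus norvegicus) (a lower number here means a stronger inhibitor, a higher number a weaker inhibitor), compound 1 `CN1CCC[C@H]1[C@H]1COc2ccc(Br)cc2O1` gives 3000 nM, level with compound 2 `CN1CCC[C@@H]1[C@@H]1COc2ccc(O)cc2O1` at 3000 nM and together with it the highest of the three numbers. Compound 3 `CN1CCC[C@H]1[C@@H]1COc2ccc(O)cc2O1` stands far lower at 12 nM. Compound 1 and compound 2 show no change at the digits printed, while compound 3 stands at a 250-fold lower number from compound 2 to compound 3 (2.40 log units; beyond the scatter). Compound 2 and compound 3 have the same atoms and bonds, so that large step rests on configuration alone, because of the fact that compounds 2 and 3 differ only in the configuration as drawn.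

Compound 4 `CN1CCC[C@H]1[C@H]1COc2ccc(O)cc2O1` differs from compound 1 by hydroxy in place of bromo on an aromatic carbon; its two stereocentres are drawn as in compound 1. Among the measured compounds shown here, no measured pair tells what bromo against hydroxy does on this core. Compound 2 carries the same hydroxy group with both stereocentres drawn the other way, and compound 3 carries it with one of them the other way. For the measured compounds named here, the only measured step, from compound 2 to compound 3, is a change of configuration, and compound 4 sits between those two arrangements. Compound 4 is therefore expected in this assay to lie between those two values, with a wide range, at 500 nM (range 50 nM to 5000 nM), which as a step means a 6.0-fold lower number from compound 1 to compound 4 (0.78 log units; beyond the scatter), expected downward.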

Compound 4, inhibition constant: 421 nM
Estimate against measurement, compound 4: 1.2-fold (0.07 log units) above, within the range that was stated.
By their numbers in this assay, from the lowest: compound 3; then compound 4; then compounds 1 and 2 (each within the scatter of the next).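

In this assay, among the compounds shown here, hydroxy in place of bromo on the aromatic carbon, with both stereocentres drawn alike, gives a 7.1-fold lower number from compound 1 to compound 4 (0.85 log units; beyond the scatter) and so supplies the first measured pair for this exchange on the shared core. With hydroxy kept in place, changing one stereocentre gives a 35-fold higher number from compound 3 to compound 4 (1.55 log units; beyond the scatter) and thus a larger step than the exchange of groups, and this step rests on configuration alone: (the fact that compounds 3 and 4 differ only in the configuration as drawn). Inverting both stereocentres gives a 7.1-fold lower number from compound 2 to compound 4 (0.85 log units; beyond the scatter) and matches the printed size of the exchange step, which shows that configuration alone can move the number as far as replacing bromo with hydroxy does here: (the fact that compounds 2 and 4 differ only in the configuration as drawn).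

The bromo compound is shown in only one arrangement, so it stays open whether the same exchange would give a step of the same size with the stereocentres drawn as in compound 3. Going by these compounds, it also stays open how an amine, a methoxy group or a carboxylic acid on that aromatic carbon would compare with hydroxy and bromo.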